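Working notes on a small growth-inhibition series

The source may report more compounds than this note shows. Statements on the series, on what has been measured and on what is new or still open speak of the compounds shown alone.

Of the compounds shown here, three have been measured so far. Compound 1 `N#C/C(=C\N1CCN(C(=O)c2ccco2)C1=S)C(N)=O` carries a carbamoyl group on its side chain; compound 2 `O=CN1CCN(C(=O)c2ccco2)C1=S` is a shorter relative; compound 3 `O=CN1CCN(c2ccc(Cl)c(Cl)c2)C1=S` replaces the furoyl portion with a dichlorophenyl group. In a functional assay on OVCAR-4 cells (Homo sapiens) for inhibition, read by sulforhodamine B assay, with a stated time of 48 h (on this read-out lower numbers stand for stronger inhibition of growth and higher numbers for weaker inhibition of growth), compound 1 gives 18500 nM. In this assay compound 2 gives 18600 nM, and compound 3 gives 18200 nM. On these numbers compound 1 stands second highest of three, but the gaps to compound 2 and compound 3 both lie within the usual scatter, so the three measured compounds cannot be told apart on this read-out. Going by the values given here, no pair of measured compounds differs in a single place, so there is no measured step to lean on.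

Compound 4 `N#C/C(=C\N1CCN(C(=O)c2ccco2)C1=S)C(=O)c1ccccc1` is the next candidate. It differs from compound 1 by phenyl in place of amino on a carbonyl carbon. Among the compounds with values here, with no measured single-place step available, and with the three measured compounds sitting on top of one another, the expectation is a step of no more than the scatter in this assay, in no preferred direction. The estimate for compound 4 in this assay is therefore 18000 nM, with a range from 6000 nM to 55000 nM, corresponding to an expected step of a 1.0-fold lower number from compound 1 to compound 4 (0.01 log units; within the scatter).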

Compound 4, concentration for 50% growth inhibition: 29800 nM
The estimate for compound 4 lay 1.7-fold (0.22 log units) below the measured number; low and high end bracket the measured number.
By their numbers in this assay, from the lowest: compounds 3, 1, 2 and 4 (each within the scatter of the next).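

Going by these compounds alone, this is the first single-place step: at the carbonyl carbon, carbamoyl gives way to benzoyl, and in this assay the step reads a 1.6-fold higher number from compound 1 to compound 4 (0.21 log units; within the scatter) and so does not separate the two compounds. At this position, then, phenyl in place of amino leaves the read-out within the scatter, even though the exchange removes the amino group's hydrogen-bond donor and brings in an aromatic ring. This single step supports no general rule about the position, and no measured information accompanies it to explain the result.

What the compounds shown leave open is whether any group on this carbonyl carbon can move the number beyond the scatter, since only amino and phenyl have been compared there. A carboxylic acid, a methyl ester, a dimethylamino group or a pyridine ring on the same carbon would test this further, and a longer chain would show whether the step stays this small as the group extends from the carbonyl carbon.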